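Variation of the group on the carbonyl carbon

A few compounds are considered here, and "the series" means these few. Any claim that something is new, unique, unknown or untested is made for them only; others in the source may bear on it.

Compound 1 `Cc1nc(S(C)(=O)=O)ccc1Oc1ncnc(OC2CCN(C(=O)OC(C)(C)CF)CC2)c1F`, compound 2 `Cc1nc(S(C)(=O)=O)ccc1Oc1ncnc(OC2CCN(C(=O)O[C@@H](C)C(F)(F)F)CC2)c1F` and compound 3 `Cc1nc(S(C)(=O)=O)ccc1Oc1ncnc(OC2CCN(C(=O)SC3(C)CC3)CC2)c1F` share one core and differ only in the group on the carbonyl carbon. In a functional assay on isolated protein for inhibition of Glucose-dependent insulinotropic receptor (Homo sapiens), read by HTRF and cAMP accumulation (a lower number here means that less compound is needed, a higher number that more compound is needed for the effect), compound 1 gives 19.9 nM, compound 2 gives 9.86 nM and compound 3 gives 13.2 nM. Compound 3 holds the second highest of the three numbers, but its steps to the others, a 1.3-fold higher number from compound 2 to compound 3 (0.13 log units; within the scatter) and a 1.5-fold lower number from compound 1 to compound 3 (0.18 log units; within the scatter), are both within the scatter. Compound 4 is `Cc1nc(S(C)(=O)=O)ccc1Oc1ncnc(OC2CCN(C(=O)c3noc(C(C)(C)F)n3)CC2)c1F`, and the change is a group of 9 heavy atoms (5 carbon, 2 nitrogen, 1 oxygen, 1 fluorine; one five-membered aromatic ring with 3 hetero atoms) in place of a group of 5 heavy atoms (4 carbon, 1 sulfur; one three-membered non-aromatic ring of carbon only), on a carbonyl carbon. Both earlier steps at this same position stayed within the scatter, so no step beyond the scatter is expected, though the entering group differs more in kind from what was tried before. Compound 4 is therefore estimated at 15 nM, range 5 nM to 45 nM, an expected step of a 1.1-fold higher number from compound 3 to compound 4 (0.06 log units; within the scatter).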

Compound 4, half-maximal effective concentration: 14 nM
For compound 4 the middle estimate is 1.1-fold (0.03 log units) above the measured one; measured number inside the range.
By their numbers in this assay, from the lowest: compounds 2, 3, 4 and 1 (each within the scatter of the next).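

In this assay, the five-membered aromatic ring with 3 hetero atoms on the carbonyl carbon stays within the scatter of all three earlier groups (a 1.1-fold higher number from compound 3 to compound 4 (0.03 log units; within the scatter) and a 1.4-fold higher number from compound 2 to compound 4 (0.15 log units; within the scatter) and a 1.4-fold lower number from compound 1 to compound 4 (0.15 log units; within the scatter)). The number at this position therefore holds even when the group changes in kind, here to 9 heavy atoms and 3 hydrogen-bond acceptors. No measured evidence on this result is available.

As far as these compounds go, whether an amine or a carboxylic acid on the carbonyl carbon would hold the number stays open. So does whether any group at this position gives a step beyond the scatter.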